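The source may hold more compounds than are shown below. What is called first, only, known or untested is meant among the compounds shown, and "the series" means these compounds.

Measured compounds:
- Compound 1, `ClCc1ccccc1Cn1cnc2c(Cl)nc(Cl)nc21`, "not determined" (no result reported) in a functional assay on SNB-75 cells (Homo sapiens) for cytotoxicity, read by sulforhodamine B assay, with a stated time of 48 h; on this read-out lower numbers stand for higher toxicity in this test and higher numbers for lower toxicity in this test
- Compound 2, `ClCc1ccccc1Cn1cnc2c(Cl)ncnc21`, 39800 nM
- Compound 3, `ClCc1cccc(Cn2cnc3c(Cl)ncnc32)c1`, 10000 nM

Three compounds share a core built from two fused rings. Compound 1 has no value in this assay. Compound 2 gives 39800 nM, the higher of the two numbers, which on this read-out means the lower toxicity. Compound 3 gives 10000 nM, a lower number than compound 2 and beyond the scatter, so compound 3 is the more toxic of the pair.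

Compound 4, `Nc1nc(Cl)c2ncn(Cc3ccccc3CCl)c2n1`, differs from compound 2 by one change: amino in place of hydrogen on an aromatic carbon. Among the measured compounds shown here, no measured pair shows what this change does in this assay. With nothing to anchor a direction, a modest step from compound 2 to compound 4 is expected, a 1.3-fold lower number from compound 2 to compound 4 (0.12 log units; within the scatter), perhaps within the scatter. Compound 4 is therefore estimated at 30000 nM, with a range from 8000 nM to 100000 nM.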

Compound 4, concentration lethal to 50% of the cells: 64600 nM
Estimate against measurement, compound 4: 2.2-fold (0.33 log units) below; the measured number falls inside the stated range.
By their numbers in this assay, from the lowest: compound 3; then compounds 2 and 4 (each within the scatter of the next).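

In this assay, placing amino instead of hydrogen on the aromatic carbon between two ring nitrogen atoms gives a 1.6-fold higher number from compound 2 to compound 4 (0.21 log units; within the scatter) and so leaves the two compounds inseparable on this read-out. Among the compounds shown here, this is the first readable result for this position, and it shows that the shared core can carry an amino group here, with its one hydrogen-bond donor, without a difference beyond the scatter in this test. No supporting measurement is available that could explain this result.

Compound 1, which carries a chloro group on the same carbon, has the entry "not determined" (no result reported) and so offers no comparison. The compounds shown leave open whether a methyl group, a hydroxyl group or a dimethylamino group on this carbon would also stay within the scatter of compound 2, or would separate from it.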